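The source may report more compounds than this note shows. Statements on the series, on what has been measured and on what is new or still open speak of the compounds shown alone.

Measured so far in a functional assay on MCF7 cells (Homo sapiens) for inhibition, read by sulforhodamine B assay, with a stated time of 48 h; on this read-out higher numbers stand for weaker inhibition of growth and lower numbers for stronger inhibition of growth:
compound 1 `COc1cc(/C=C/C2CC(=O)C=CO2)cc(OC)c1OC`: 149 uM
compound 2 `COc1ccc(/C=C/C2CC=CC(=O)O2)cc1OC`: 7.8 uM
compound 3 `COc1cc(/C=C/C2CC=CC(=O)O2)cc(OC)c1`: 9.5 uM

Compound 3 gives the second highest of the three numbers. Its nearest neighbour is compound 2, whose number sits lower by a margin that lies within the scatter, so the two cannot be ordered. Compound 1, built on a different core, gives a number that lies beyond the scatter higher than that of compound 3.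

Compound 4 `COc1cc(/C=C/C2CC=CC(=O)O2)cc(OC)c1OC` keeps the core of compound 3 and differs from it in one place: methoxy in place of hydrogen on an aromatic carbon. Going by the values given here, no pair of measured compounds shows this change on this core, so the size of the step has no direct precedent. Compound 1 bears the same arrangement of methoxy groups as compound 4 but on another core, so its number says nothing separable about the added methoxy. The step from compound 3 to compound 4 is expected to be a 1.1-fold higher number from compound 3 to compound 4 (0.02 log units; within the scatter), none beyond the scatter. On this basis compound 4 is estimated at 10 uM, with a range from 3 uM to 35 uM.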

Compound 4, concentration for growth inhibition (reported as GI): 15.3 uM
The estimate for compound 4 lay 1.5-fold (0.18 log units) below the measured number, and the stated range covers the measured number.
By their numbers in this assay, from the lowest: compounds 2, 3 and 4 (each within the scatter of the next); then compound 1.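

In this assay, methoxy in place of hydrogen on the aromatic carbon ortho to two methoxy groups and para to a group of 9 heavy atoms gives a 1.6-fold higher number from compound 3 to compound 4 (0.21 log units; within the scatter), and the same kind of change on compound 2 gives a 2.0-fold higher number from compound 2 to compound 4 (0.29 log units; within the scatter), so on the shared core neither step can be told from the scatter. With the arrangement of methoxy groups now matched, a 9.7-fold lower number from compound 1 to compound 4 (0.99 log units; beyond the scatter) isolates the change of core, and this step lies beyond the scatter. No measurement shown gives a reason for either result.

On these data alone, whether this aromatic carbon accepts groups other than methoxy, such as a hydroxyl, an amine or a longer alkoxy chain, remains open. Also open, as far as these compounds go, is whether methoxy in place of hydrogen has the same small effect on the core of compound 1.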